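The compounds below may be only part of what the source reports. "The series", "measured", "known", "first", "only" and "open" are said of these compounds alone.

Three compounds have measurements. In an ADME assay on cells (Hepatocyte, Rattus norvegicus) for metabolic stability (on this read-out lower numbers stand for slow clearance and higher numbers for fast clearance), compound 1 `Cc1ccc2[nH]c(C(=O)N[C@H]3CCN(S(=O)(=O)N(C)C)C[C@@H]3C(=O)NCCN(C)C)cc2c1` gives 10 uL/min. Compound 3 `Cc1oc(-c2ccc(Cl)cc2)nc1C(=O)N[C@H]1CN(S(=O)(=O)c2ccccc2)C[C@@H]1C(=O)N[C@H]1CCCNC1` gives 1 uL/min. Compound 2 `Cc1csc(C(=O)N[C@H]2CN(S(=O)(=O)c3ccccc3)C[C@@H]2C(=O)N[C@H]2CCCNC2)n1` gives < 1 uL/min, which is a limit of the assay and not a number. Compound 2 thus stands at the limit of < 1 uL/min in this assay, at which 1 of the 3 values shown sits, and only a bound, not a value, is known for it. Compound 4 `O=C(N[C@H]1CN(S(=O)(=O)c2ccccc2)C[C@@H]1C(=O)N[C@H]1CCCNC1)c1cc(-c2ccc(Cl)cc2)on1` has not yet been measured; it differs from compound 2 by 5-(4-chlorophenyl)-1,2-oxazol-3-yl in place of 4-methyl-1,3-thiazol-2-yl on a carbonyl carbon. For the measured compounds named here, no measured pair isolates this change, so the step itself is unknown. Compound 2 already sits at the floor of this assay, so a move downward cannot show; compound 4 is expected to stay low, with at most a small upward step. Compound 4 is estimated at 1.5 uL/min, between 0.5 uL/min and 5 uL/min, a step of an at least 1.5-fold higher number from compound 2 to compound 4 (0.17 log units; that floor lies within the scatter).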

Compound 4, intrinsic clearance in a liver preparation (reported as CLH), per the amount of preparation that the assay uses: 2.22 uL/min
The estimate for compound 4 lay 1.5-fold (0.17 log units) below the measured number; the measured number falls inside the stated range.
By their numbers in this assay, from the lowest: compound 3; then compound 4; then compound 1.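

In this assay, this carbonyl-carbon position now shows a readable change: 5-(4-chlorophenyl)-1,2-oxazol-3-yl in place of 4-methyl-1,3-thiazol-2-yl gives an at least 2.2-fold higher number from compound 2 to compound 4 (0.34 log units; beyond the scatter). The larger group therefore does not keep the number at the floor of the assay. The true size of the step remains unknown, since compound 2 has only a limit and not a number: the limit of < 1 uL/min in this assay, at which 1 of the 4 values shown sits.

Going by these compounds, it remains open whether the step follows the chlorophenyl part or the five-membered aromatic ring. Nor do the compounds shown tell how an amine or a carboxylic acid in place of the chlorine would read.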